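Chain length and amine ring substitution in a chalcone series

A few compounds are considered here, and "the series" means these few. Any claim that something is new, unique, unknown or untested is made for them only; others in the source may bear on it.

Three measured compounds share a chalcone core carrying a basic side chain. Compound 1 `CCN(CCCCCCOc1ccc(C(=O)/C=C/c2ccc(N(C)C)cc2)c(O)c1)Cc1ccccc1N(C)C` gives 37800 nM in an assay on isolated protein for inhibition of Amine oxidase [flavin-containing] A (Homo sapiens); on this read-out lower numbers stand for stronger inhibition and higher numbers for weaker inhibition. Compound 2 `CCN(CCCOc1ccc(C(=O)/C=C/c2ccc(N(C)C)cc2)c(O)c1)Cc1ccccc1N(C)C` gives 23600 nM in this assay, and compound 3 `CCN(CCCOc1ccc(C(=O)/C=C/c2ccc(N(C)C)cc2)c(O)c1)Cc1ccc(N(C)C)cc1` gives 57500 nM. The difference between the cores of compound 1 and compound 2 is not broken down here. Between compound 2 and compound 3 the change is 4-(dimethylamino)phenyl in place of 2-(dimethylamino)phenyl on a saturated chain carbon bound to an amine nitrogen, and this gave a 2.4-fold higher number from compound 2 to compound 3 (0.39 log units; beyond the scatter). Compound 4 `CCN(CCCCCCOc1ccc(C(=O)/C=C/c2ccc(N(C)C)cc2)c(O)c1)Cc1ccc(N(C)C)cc1` is not yet measured; it differs from compound 1 by the same change, (4-(dimethylamino)phenyl in place of 2-(dimethylamino)phenyl on a saturated chain carbon bound to an amine nitrogen). Because compound 1 stands at 37800 nM and the earlier step ran a 2.4-fold higher number from compound 2 to compound 3 (0.39 log units; beyond the scatter), a step of comparable size, a 2.1-fold higher number from compound 1 to compound 4 (0.33 log units; beyond the scatter), is expected. Compound 4 is therefore estimated at 80000 nM, with a likely range from 40000 nM to 160000 nM.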

Compound 4, half-maximal inhibitory concentration: 53600 nM
The estimate for compound 4 lay 1.5-fold (0.17 log units) above the measured number, and the stated range covers the measured number.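

Carried to the core of compound 1, the change gave a 1.4-fold higher number from compound 1 to compound 4 (0.15 log units; within the scatter) in this assay. Set beside the earlier step, this result shows no measurable difference between the two cores: the same change on two cores in this assay, a 2.4-fold higher number (0.39 log units; beyond the scatter) from compound 2 to compound 3 and a 1.4-fold higher number (0.15 log units; within the scatter) from compound 1 to compound 4, 1.7-fold (0.24 log units) apart, within the scatter of two such steps. The change is therefore compatible with carrying over between these two cores, but the new step alone cannot be distinguished from scatter, and two cores do not establish a rule for the series.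

The compounds shown leave open how a benzyl group carrying methoxy or chlorine instead of dimethylamino would read in this assay. They also leave open whether the comparison would hold on a chain longer than that of compound 1.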